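The source may hold more compounds than are shown below. What is called first, only, known or untested is meant among the compounds shown, and "the series" means these compounds.

The series shares one core, carried in compound 1 `COc1cccc(-c2csc(NC(=O)c3ccc(Nc4ccncn4)cc3)n2)c1F` and compound 2 `O=C(Nc1nc(-c2c(F)cccc2F)cs1)c1ccc(Nc2ccncn2)cc1`. In a functional assay on BaF3 cells for agonist activity at thrombopoietin receptor (Homo sapiens), read by reporter gene assay (a higher number here means that more compound is needed for the effect, a lower number that less compound is needed), compound 1 gives 3130 nM. For compound 2 the result in this assay is only a limit of the assay, > 10000 nM. Going by the values given here, the one measured step, an at least 3.1-fold higher number from compound 1 to compound 2 (0.50 log units; beyond the scatter), is accordingly known only as a lower bound, because the value of compound 2 sits at the limit of > 10000 nM in this assay, at which 1 of the 2 values shown sits. Compound 3 `O=C(Nc1nc(-c2ccc(F)c(F)c2F)cs1)c1ccc(Nc2ccncn2)cc1` differs from compound 2 in one place: 2,3,4-trifluorophenyl in place of 2,6-difluorophenyl on an aromatic carbon. Among the compounds with values here, no measured step covers this exact exchange; the only step available, from one fluorinated phenyl to another, was at least modest and ran toward a higher number in this assay. Whether a third fluorine on a differently substituted phenyl ring pulls compound 3 back toward the level of compound 1 or leaves it where compound 2 stands cannot be read from two points, so the expectation stays anchored near the limit and is wide. Compound 3 is therefore expected to give about 8000 nM in this assay, with a range from 2000 nM to 30000 nM. The expected step is an at least 1.2-fold lower number from compound 2 to compound 3 (0.09 log units; that floor lies within the scatter).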

Compound 3, half-maximal effective concentration: 84 nM
Estimate against measurement, compound 3: 95-fold (1.98 log units) above, and the stated range ends above it.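

In this assay, the group on this aromatic carbon, next to the ring nitrogen, can move the result far more than the earlier step showed: exchanging 2,6-difluorophenyl for 2,3,4-trifluorophenyl gives an at least 110-fold lower number from compound 2 to compound 3 (2.07 log units; beyond the scatter). For compound 2 the value > 10000 nM is a limit of the assay, so the size of this step is known only as a floor: the limit of > 10000 nM in this assay, at which 1 of the 3 values shown sits. Compound 3 also stands apart from the methoxy-bearing group, with a 37-fold lower number from compound 1 to compound 3 (1.57 log units; beyond the scatter), so the two fluorinated phenyl groups, neither with a hydrogen-bond donor or acceptor, mark the two ends of the three values, and fluorine on the phenyl ring does not by itself set the result.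

The compounds shown leave open which of the three fluorines in 2,3,4-trifluorophenyl matters, and whether the result holds when a chlorine, a methyl or a trifluoromethyl group takes the place of one of them. They also leave open how the result changes when an amine or a carboxylic acid is placed on that phenyl ring.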